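The source may hold more compounds than are shown below. What is called first, only, known or untested is meant among the compounds shown, and "the series" means these compounds.

In a functional assay on BXPC-3 cells (Homo sapiens) for cytotoxicity, read by MTT assay, with a stated time of 72 h (on this read-out higher numbers stand for weaker inhibition and lower numbers for stronger inhibition), three compounds built on one shared core have been measured. Compound 1 `O=C1C(Nc2ccc(Oc3ccccc3)cc2)=CC(=O)c2ncncc21` gives 3600 nM. Compound 3 `O=C1C(Nc2ccc(-c3ccc(F)cc3)cc2)=CC(=O)c2ncncc21` gives 4400 nM and so holds the higher of the two actual numbers, yet a 1.2-fold higher number from compound 1 to compound 3 (0.09 log units; within the scatter), so the two stand level. Compound 2 `NC(=O)c1ccc(NC2=CC(=O)c3ncncc3C2=O)cc1` reaches only the limit > 10000 nM, which is a limit of the assay rather than a number (the limit of > 10000 nM in this assay, at which 1 of the 3 values shown sits).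

Compound 4 `O=C1C(Nc2ccc(CO)cc2)=CC(=O)c2ncncc21` has not yet been measured in this assay. It differs from compound 3 in one place (hydroxymethyl in place of 4-fluorophenyl on an aromatic carbon).

Going by the values given here, three measured steps bear on this change. Swapping one aromatic group for another left the number unmoved: a 1.2-fold higher number from compound 1 to compound 3 (0.09 log units; within the scatter). Replacing an aromatic group with a small group that is not a ring, however, weakened inhibition: an at least 2.7-fold higher number from compound 1 to compound 2 (0.44 log units; beyond the scatter), and in the reverse direction an at least 2.2-fold lower number from compound 2 to compound 3 (0.35 log units; beyond the scatter). The move to hydroxymethyl resembles this second kind of change, so a weaker number, possibly again only a limit, is expected for compound 4. The estimate for compound 4 is 12000 nM, with a range from 4000 nM to 40000 nM. That estimate means a 2.7-fold higher number from compound 3 to compound 4 (0.44 log units; beyond the scatter), a step expected to fall beyond the scatter toward weaker inhibition.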

Compound 4, half-maximal inhibitory concentration: 5700 nM
Compound 4: middle estimate off by 2.1-fold (0.32 log units), on the high side; low and high end bracket the measured number.
By their numbers in this assay, from the lowest: compounds 1, 3 and 4 (each within the scatter of the next). At a limit, above all of these: compound 2.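

In this assay, a group with no ring can take the place of the 4-fluorophenyl on the aromatic carbon without a change beyond the scatter (a 1.3-fold higher number from compound 3 to compound 4 (0.11 log units; within the scatter)), and the same holds against the phenoxy group (a 1.6-fold higher number from compound 1 to compound 4 (0.20 log units; within the scatter)). The earlier compounds held only two ring-bearing groups that stood level and one group without a ring that stood apart, so a ring at this place could have seemed necessary; hydroxymethyl, with far fewer heavy atoms than 4-fluorophenyl, shows that among these compounds it is not. Compound 2 goes against any simple rule that groups without a ring are tolerated here, since its carbamoyl leaves it at a limit rather than a number: the limit of > 10000 nM in this assay, at which 1 of the 4 values shown sits.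

Hydroxymethyl and carbamoyl cannot yet be firmly separated, as the step between them has a floor within the scatter (an at least 1.7-fold lower number from compound 2 to compound 4 (0.24 log units; that floor lies within the scatter)). On these data alone, how an amine, a carboxylic acid or a longer chain ending in hydroxyl would behave at this place stays open, and so does whether the hydrogen-bond donor and acceptor of hydroxymethyl matter at all.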